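The source may hold more compounds than are shown below. What is called first, only, known or untested is meant among the compounds shown, and "the series" means these compounds.

Series values in a functional assay on HepG2 cells (Homo sapiens) for inhibition, read by MTT assay, with a stated time of 48 h; a lower number here means a stronger inhibitor, a higher number a weaker inhibitor:

Compound 1 `COc1ccc(CSc2nnc(-c3cc(OC)c(OC)c(OC)c3)n2-c2ccc(N(C)C)cc2)cc1`: > 60000 nM, which is a limit of the assay and not a number.
Compound 2 `COc1ccc(C(=O)CSc2nnc(-c3cc(OC)c(OC)c(OC)c3)n2-c2ccc(N(C)C)cc2)cc1`: 18800 nM.

Among the measured compounds shown here, compound 2, at 18800 nM, holds the only numeric value so far, so it cannot yet be ranked against a measured number. Compound 3 `COc1ccc(C(=O)CSc2nnc(-c3cc(OC)c(OC)c(OC)c3)n2-c2ccc(N(C)C)cc2)cc1O` adds one change to compound 2: hydroxy in place of hydrogen on an aromatic carbon, ortho to a methoxy group and meta to a large group, giving 3-hydroxy-4-methoxyphenyl (hydroxy in place of hydrogen on an aromatic carbon). For the measured compounds named here, the only measured step, an at least 3.1-fold lower number from compound 1 to compound 2 (0.50 log units; beyond the scatter), altered the same side group through a different change, and its size rests on (the limit of > 60000 nM in this assay, at which 1 of the 2 values shown sits). It therefore offers weak guidance on size. A small move towards a lower number is expected, not clearly beyond the scatter. The expected step is a 1.9-fold lower number from compound 2 to compound 3 (0.27 log units; within the scatter). The estimate for compound 3 is 10000 nM, with an expected range of 2000 nM to 40000 nM.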

Compound 3, half-maximal inhibitory concentration: > 100000 nM
Compound 3: a limit, no number; the forecaster's own chance of this, stated with the estimate: 10%; middle value at least 10-fold (1.00 log units) from the limit.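

In this assay, compound 3 gives > 100000 nM, which is a limit of the assay and not a number. Even so, hydroxy in place of hydrogen on an aromatic carbon, ortho to a methoxy group and meta to a large group, gives an at least 5.3-fold higher number from compound 2 to compound 3 (0.72 log units; beyond the scatter), so the aromatic ring of the (4-methoxyphenyl)carbonyl group is sensitive at this position to a single added hydroxy, and this is the first change shown that moves the number upward. The step linking compound 1 and compound 3 cannot be read, since both values are limits.

Going by these compounds, it remains open whether this shift is specific to hydroxy or would also follow from a fluorine, an amine or a second methoxy group at the same place. The true size of the step also remains open, since it rests on a limit: the limit of > 100000 nM in this assay, at which 1 of the 3 values shown sits.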